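Removing a methyl from the aryl ether of compound 2

The source may hold more compounds than are shown below. What is called first, only, known or untested is meant among the compounds shown, and "the series" means these compounds.

Among the measured compounds shown here, compound 2 `COc1cc(-c2nn(-c3cccc(NC(=O)Nc4cc(C(F)(F)F)cc(C(F)(F)F)c4)c3)cc2-c2ccncc2)ccc1Cl` is the one compound here with a firm number: in a functional assay on Malme-3M cells (Homo sapiens) for inhibition, read by sulforhodamine B assay, with a stated time of 48 h (a lower number here means that less compound is tolerated, a higher number that more compound is tolerated), compound 2 gives 7680 nM. For the measured compounds named here, compound 1 `O=C(Nc1cccc(-n2cc(-c3ccncc3)c(-c3ccc(Cl)c(O)c3)n2)c1)Nc1cccc(C(F)(F)F)c1` differs from compound 2 in two places, so no single step links them. In this assay compound 1 reaches only a limit, > 32500 nM, and is therefore not a measured number. Compound 3 `O=C(Nc1cccc(-n2cc(-c3ccncc3)c(-c3ccc(Cl)c(O)c3)n2)c1)Nc1cc(C(F)(F)F)cc(C(F)(F)F)c1` has not yet been tested. It is compound 2 with one change: hydrogen in place of methyl on an oxygen on an aromatic ring. Going by the values given here, with no measured pair sharing this change, the expected direction rests on compound 1, which carries the same hydroxy group and sits at the limit (the limit of > 32500 nM in this assay, at which 1 of the 2 values shown sits). Compound 3 is therefore expected to be tolerated somewhat more than compound 2, with the step from compound 2 to compound 3 estimated at a 2.1-fold higher number from compound 2 to compound 3 (0.32 log units; beyond the scatter). The estimate for compound 3 in this assay is 16000 nM, within a range from 5000 nM to 40000 nM.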

Compound 3, concentration lethal to 50% of the cells: 23500 nM
For compound 3 the middle estimate is 1.5-fold (0.17 log units) below the measured one; the range from low to high includes it.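

Among the compounds shown here, this is the one measured pair for this change, and in this assay going from methoxy to hydroxy gives a 3.1-fold higher number from compound 2 to compound 3 (0.49 log units; beyond the scatter), so swapping methyl for hydrogen on this oxygen alone moves the number beyond the scatter. The other step, adding a trifluoromethyl on an aromatic carbon, gives an at least 1.3-fold lower number from compound 1 to compound 3 (0.14 log units; that floor lies within the scatter), and since its floor lies within the scatter it shows no firm effect of that group. Compound 1 stands at a limit and not at a number: the limit of > 32500 nM in this assay, at which 1 of the 3 values shown sits.

A single pair cannot tell whether the same step would appear with other groups elsewhere on the molecule. From the compounds shown here alone, whether an ethoxy group or an amine in place of the methoxy would shift the number further also remains open.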